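Aryl swap on compound 2: expected maximal response

The compounds below may be only part of what the source reports. "The series", "measured", "known", "first", "only" and "open" are said of these compounds alone.

Three compounds have numbers in an in vitro functional assay on HEK285-7 cells for antagonist activity at prostaglandin D2 receptor 2 (Homo sapiens), read by BRET and beta-arrestin recruitment; on this read-out higher numbers stand for larger maximal responses and lower numbers for smaller maximal responses. Compound 1 `Nc1nc(-c2ccc(Cl)cc2)c(CC(=O)O)s1` gives 50%. Compound 3 `O=C(O)Cc1sc(COc2ccc(Cl)cc2)nc1-c1ccc(Cl)cc1` gives 50%. Compound 2 `CS(=O)(=O)Nc1cccc(-c2nc(C(c3ccc(F)cc3)c3ccc(F)cc3)sc2CC(=O)O)c1` gives 80%, the highest of the three; its nearest neighbour, compound 1, lies lower by a margin beyond the scatter, and compound 3, equally far below, is likewise beyond the scatter.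

Compound 4 `Nc1cc(-c2nc(C(c3ccc(F)cc3)c3ccc(F)cc3)sc2CC(=O)O)cc(F)n1` is not yet measured. It differs from compound 2 in one place:

2-amino-6-fluoropyridin-4-yl in place of 3-(methanesulfonamido)phenyl on an aromatic carbon

The exchange sits on an aromatic carbon of the five-membered aromatic ring with 1 nitrogen and 1 sulfur, next to the ring nitrogen and next to the ring atom that bears the carboxymethyl group. No measured pair isolates this kind of exchange, so its effect on the largest response is not anchored by any shown step. The expected step is a number 10 percentage points lower from compound 2 to compound 4 (within the scatter), a modest downward movement that stays near the edge of the scatter. For compound 4 the estimate is 70%, within a range of 45% to 90%.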

Compound 4, largest response reached (reported as efficacy), in percent of the reference or control that the assay uses: 30%
The estimate for compound 4 lay 40 percentage points above the measured number, outside the stated range (below it).
By their numbers in this assay, from the lowest: compound 4; then compounds 1 and 3 (each within the scatter of the next); then compound 2.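

The aromatic carbon next to the ring nitrogen is sensitive to the group it carries: in this assay there is a number 50 percentage points lower from compound 2 to compound 4 (beyond the scatter) when 2-amino-6-fluoropyridin-4-yl replaces 3-(methanesulfonamido)phenyl. Compounds 1, 2 and 3 differ from one another in more than one place, so they could not isolate the contribution of this aryl group to the maximal response. No supporting measurement bears on why the response falls with this exchange.

The methanesulfonamido group leaves while the pyridine ring nitrogen, the amino group and the fluorine enter together, so the compounds shown leave open which part of the exchange goes with the step. A 3-aminophenyl or a 2-aminopyridin-4-yl group on the same carbon would help separate these parts.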